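Anilide substituent change from compound 3 to compound 4

A few compounds are considered here, and "the series" means these few. Any claim that something is new, unique, unknown or untested is made for them only; others in the source may bear on it.

Three measured compounds share one core and differ only in the group on the amide-type nitrogen. Compound 1 `O=C(CCC(=O)OCCCCCCSc1ccc([N+](=O)[O-])c2nonc12)Nc1ccccc1F` carries a fluoro on that aromatic carbon; in an ADME assay on HUVEC cells (Homo sapiens) for cytotoxicity, read by MTT assay, with a stated time of 72 h (a lower number here means a stronger inhibitor, a higher number a weaker inhibitor), compound 1 gives 840 nM. Compound 2 `O=C(CCC(=O)OCCCCCCSc1ccc([N+](=O)[O-])c2nonc12)Nc1ccccc1Cl` carries a chloro in its place, and in this assay compound 2 gives 2950 nM. Compound 3 `Cc1ccccc1NC(=O)CCC(=O)OCCCCCCSc1ccc([N+](=O)[O-])c2nonc12` carries a methyl, and in this assay compound 3 gives 1410 nM, the second highest of the three numbers, nearest to compound 1 and furthest from compound 2. The measured steps are a 3.5-fold higher number from compound 1 to compound 2 (0.55 log units; beyond the scatter), a 1.7-fold higher number from compound 1 to compound 3 (0.22 log units; within the scatter) and a 2.1-fold lower number from compound 2 to compound 3 (0.32 log units; beyond the scatter).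

Compound 4 `O=C(CCC(=O)OCCCCCCSc1ccc([N+](=O)[O-])c2nonc12)Nc1ccc(F)cc1` has not been measured. The change is 4-fluorophenyl in place of 2-methylphenyl on an amide-type nitrogen. Among the measured compounds shown here, it has two parts: fluoro returns in place of methyl, the reverse of the step between compound 1 and compound 3 that lay within the scatter, and the ring is now substituted as 4-fluorophenyl rather than 2-methylphenyl, a difference no measured pair covers. On the fluoro-for-methyl part alone, compound 4 is expected close to compound 1 because compound 1 gives 840 nM and compound 3 gives 1410 nM, the two sitting within the scatter of each other. The step is therefore expected as a 1.4-fold lower number from compound 3 to compound 4 (0.15 log units; within the scatter), not beyond the scatter in either direction. Compound 4 is estimated at 1000 nM, with a range of 400 nM to 2800 nM in this assay.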

Compound 4, half-maximal inhibitory concentration: 1740 nM
Estimate against measurement, compound 4: 1.7-fold (0.24 log units) below; the measured number falls inside the stated range.
By their numbers in this assay, from the lowest: compounds 1, 3, 4 and 2 (each within the scatter of the next, the first and the last beyond it).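

In this assay the contrast a 2.1-fold higher number from compound 1 to compound 4 (0.32 log units; beyond the scatter) keeps fluoro and replaces 2-fluorophenyl with 4-fluorophenyl on the amide-type nitrogen, which shows that where the fluoro stands on the ring can alone produce a step beyond the scatter. The other two new steps do not separate the groups: a 1.2-fold higher number from compound 3 to compound 4 (0.09 log units; within the scatter) and a 1.7-fold lower number from compound 2 to compound 4 (0.23 log units; within the scatter) both lie within the scatter, so 4-fluorophenyl cannot be told apart from 2-methylphenyl or 2-chlorophenyl at this position. Fluoro alone therefore does not place a compound at the low end of the series, and compound 1 stands apart from compound 2 and compound 4 but not from compound 3.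

Left open is whether chloro or methyl would respond to the same shift on the ring as fluoro does, and how an amine or a carboxylic acid on the ring, or a longer alkyl chain in place of the ring, would read at this nitrogen in this assay as well. No supporting measurement is available to explain the difference between the 2-fluorophenyl and 4-fluorophenyl compounds.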